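Ethyl on the thiophene ring: a step from compound 1

The source may hold more compounds than are shown below. What is called first, only, known or untested is meant among the compounds shown, and "the series" means these compounds.

Measured compounds:
compound 1, `O=C(Nc1ccc(Cl)cc1)NS(=O)(=O)c1cccs1`: 16%
compound 2, `Cc1ccc(S(=O)(=O)NC(=O)Nc2ccc(Cl)c(Cl)c2)s1`: 24%

In a functional assay on the whole organism (6C3HED cells, Mus musculus) for inhibition, at a dose of 150 mg/kg by the oral route (on this read-out lower numbers stand for less inhibition and higher numbers for more inhibition at the one dose given (going by the name of the read-out)), compound 1 gives 16% and compound 2 gives 24%. The two numbers lie within the scatter of each other, so neither compound stands apart on this read-out. Compound 3, `CCc1csc(S(=O)(=O)NC(=O)Nc2ccc(Cl)cc2)c1`, has not yet been measured. It differs from compound 1 by ethyl in place of hydrogen on an aromatic carbon. Among the measured compounds shown here, no measured pair shows this change, so the step is expected to be small, within the scatter, with at most a slight rise: a number 6 percentage points higher from compound 1 to compound 3 (within the scatter). For compound 3 the estimate is 22%, ranging from 8% to 38%.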

Compound 3, a percentage reported as inhibition, in the whole organism at one dose (the size of the read-out at that dose, not a potency): 55%
Compound 3: the middle estimate sits 33 percentage points below what was measured; measured number outside the range, above it.
By their numbers in this assay, from the lowest: compounds 1 and 2 (each within the scatter of the next); then compound 3.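

In this assay, ethyl in place of hydrogen on this aromatic carbon, two ring bonds from the ring sulfur, gives a number 39 percentage points higher from compound 1 to compound 3 (beyond the scatter). This single change moves the read-out beyond the scatter, so this position of the five-membered ring is not indifferent to what it carries. Nothing available accounts for the rise.

As far as these compounds go, whether a longer chain, such as propyl, or an amine on the same carbon would give a similar number remains open. So does whether ethyl would have the same effect on another ring carbon.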